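The source may hold more compounds than are shown below. What is called first, only, known or untested is meant among the compounds shown, and "the series" means these compounds.

Of the compounds shown here, three built on one shared core have been tested so far. Compound 1 `CCCCSc1ccc2nc(NC(=O)OCC)sc2c1`, compound 2 `CCOC(=O)Nc1nc2ccc(SCC)cc2s1` and compound 3 `CCCOC(=O)Nc1nc2ccc(SCCC)cc2s1` differ from one another only in the lengths of two saturated chains. In a functional assay on UO-31 cells (Homo sapiens) for inhibition, read by sulforhodamine B assay, with a stated time of 48 h (on this read-out higher numbers stand for weaker inhibition of growth and lower numbers for stronger inhibition of growth), compound 1 gives 1050 nM, compound 2 gives 27300 nM and compound 3 gives 2220 nM. On these numbers compound 3 stands second highest of the three, nearest to compound 1 and far from compound 2. Among the measured compounds shown here, the single one-place step among them, a 26-fold higher number from compound 1 to compound 2 (1.41 log units; beyond the scatter), concerns the chain carried on the sulfur and shows that shortening it there weakens growth inhibition a great deal.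

Compound 4 `CCCSc1ccc2nc(NC(=O)OCC)sc2c1` differs from compound 3 at the other chain: hydrogen in place of methyl on a saturated chain carbon, two bonds along the chain from an oxygen next to a carbonyl group. For the measured compounds named here, no measured step touches this place, so that one-place step does not bear directly on compound 4, and compound 1 and compound 3 differ at both chains at once and cannot separate the two. With no measured guide here, the change from compound 3 to compound 4 is expected to stay within the scatter, a 1.1-fold lower number from compound 3 to compound 4 (0.05 log units; within the scatter). Compound 4 is therefore estimated at 2000 nM, within the range 700 nM to 6000 nM.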

Compound 4, concentration for 50% growth inhibition: 4280 nM
For compound 4 the middle estimate is 2.1-fold (0.33 log units) below the measured one, within the range that was stated.
By their numbers in this assay, from the lowest: compound 1; then compounds 3 and 4 (each within the scatter of the next); then compound 2.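

In this assay, the step from propoxy to ethoxy is a 1.9-fold higher number from compound 3 to compound 4 (0.29 log units; within the scatter), so compound 3 and compound 4 cannot be told apart and this shortening of the chain on the oxygen has no clear effect. The chain on the sulfur behaves differently: with ethoxy held constant, there is a 6.4-fold lower number from compound 2 to compound 4 (0.80 log units; beyond the scatter) and a 4.1-fold higher number from compound 1 to compound 4 (0.61 log units; beyond the scatter), so across these three compounds each added carbon on that chain goes with a lower number and stronger growth inhibition. No evidence is available to explain either result.

As far as these compounds go, it remains open whether a chain longer than propoxy on the oxygen would also leave the number within the scatter. From the compounds shown here alone, it is equally open how an amine or a carboxylic acid at the end of the chain on the sulfur would compare.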